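The source may report more compounds than this note shows. Statements on the series, on what has been measured and on what is new or still open speak of the compounds shown alone.

Compound 1 `CC(C)COc1ncc(-c2cn(C)c3cc(C(=O)NS(C)(=O)=O)ccc23)cc1Cl` was examined in an ADME assay on microsomes from liver (Homo sapiens) for metabolic stability, with a stated time of 10 min, tested at 0.5 uM (a higher number here means that more of the compound is left, a lower number that less of the compound is left), and gave 95%. Two companions share part of its shape. Compound 2 `CC(C)Cc1ccc(-c2cn(C)c3cc(C(=O)NS(C)(=O)=O)ccc23)cc1` gave 100% in this assay, and compound 3 `Cn1cc(-c2ccc(C(F)(F)F)cc2)c2cc(F)c(C(=O)NS(=O)(=O)C3CC3)cc21` gave 100% in this assay. Taken together, the three numbers lie close to one another: the gap from compound 1 to compound 2 and the gap from compound 1 to compound 3 are both within the scatter of this kind of measurement, so nothing separates compound 1 from its companions, and none of the three can be called more or less stable than another on these data.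

Compound 4 `CC(C)COc1ncc(-c2cn(C)c3cc(C(=O)NS(C)(=O)=O)c(F)cc23)cc1Cl` is the next member and has not yet been measured. It differs from compound 1 in one place (fluoro in place of hydrogen on an aromatic carbon). Compound 3 already carries a fluoro on the same kind of position, and its value is indistinguishable from that of compound 1, so the expectation for compound 4 in this assay is no step beyond the scatter in either direction: an estimated no change at the digits printed from compound 1 to compound 4 (within the scatter). Compound 4 is therefore expected to give about 95%, in a range from 85% to 100%.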

Compound 4, percent of the compound remaining: 100%
Compound 4: middle estimate off by 5 percentage points, on the low side, and the stated range covers the measured number.
By their numbers in this assay, from the lowest: compounds 1, 2, 3 and 4 (each within the scatter of the next).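

Read in this assay, the fluoro in place of hydrogen on an aromatic carbon, ortho to the (methylsulfonyl)carbamoyl group, gives a number 5 percentage points higher from compound 1 to compound 4 (within the scatter), and this is the first view of a change in one place alone on the core of compound 1. Among these compounds, it shows that this position accepts a fluoro with no step that can be told from the scatter, although compound 1 already stands at 95%, leaving this read-out little room to register any rise. Nothing at hand bears on the reason for this result.

The compounds shown leave open whether a chloro, a methoxy group or an amine on this same aromatic carbon would also stay within the scatter, and whether the same fluoro would behave alike on the core of compound 2. Among the compounds shown here, they also leave open whether this position matters at all under conditions in which a clearly smaller share of compound 1 remains, as all the numbers so far sit close together at the top of the scale.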